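The source may report more compounds than this note shows. Statements on the series, on what has been measured and on what is new or still open speak of the compounds shown alone.

Values in an ADME assay on HEK293 cells (Homo sapiens) for inhibition, read by MTT assay, with stated times of 18 h and 4 h; a higher number here means a weaker inhibitor, a lower number a stronger inhibitor:

Compound 1 `CCCCCCCCCCCCCCCCOP(=O)(O)OCCSC(=S)N1CCCCCC1`: > 100000 nM (a limit of the assay, not a number)
Compound 2 `CCCCCCCCOP(=O)(O)OCCSC(=S)N1CCCC1`: 28300 nM
Compound 3 `CCCCCCCCCCOP(=O)(O)OCCSC(=S)N1CCCCCC1`: 70000 nM

Of the two true numbers, the higher belongs to compound 3, at 70000 nM. Compound 2 lies lower at 28300 nM, a gap beyond the scatter.

The change of interest leads to compound 4 `CCCCCCCCCCOP(=O)(O)OCCSC(=S)N1CCCC1`, which keeps the decyl chain of compound 3 but has pyrrolidin-1-yl in place of azepan-1-yl on a thiocarbonyl carbon.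

For the measured compounds named here, no measured step changes this ring alone. Going by the values given here, the one step available, an at least 1.4-fold lower number from compound 1 to compound 3 (0.15 log units; that floor lies within the scatter), lies on the chain, so it offers little guidance here. The better guide is compound 2, at 28300 nM, which shares pyrrolidin-1-yl with compound 4 but carries an octyl chain. A moderate shift towards stronger inhibition therefore seems likely, landing between the two true numbers.

An estimated 1.8-fold lower number from compound 3 to compound 4 (0.24 log units; within the scatter) is expected in this assay.

Compound 4 is expected at 40000 nM, with an estimated range from 18000 nM to 85000 nM.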

Compound 4, half-maximal inhibitory concentration: > 100000 nM
Compound 4: a limit, no number (the forecaster's own chance of this, stated with the estimate: 10%); at least 2.5-fold (0.39 log units) between middle value and limit.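

In this assay compound 4 gives > 100000 nM, a limit of the assay and not a number: the limit of > 100000 nM in this assay, at which 2 of the 4 values shown sit.

With the decyl chain held fixed, placing pyrrolidin-1-yl for azepan-1-yl on the thiocarbonyl carbon gives an at least 1.4-fold higher number from compound 3 to compound 4 (0.15 log units; that floor lies within the scatter), so this ring change brought no measurable gain in inhibition, although a floor of this size cannot be told apart from scatter. With pyrrolidin-1-yl held fixed, the step from the octyl chain to the decyl chain gives an at least 3.5-fold higher number from compound 2 to compound 4 (0.54 log units; beyond the scatter), which shows that at this ring the chain length matters clearly.

On these data alone, the true size of the ring step stays unknown while compound 4 has only a limit. Also open, as far as these compounds go, is whether a piperidin-1-yl ring in this place, or a hexyl chain on the pyrrolidin-1-yl compounds, would give a lower number.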